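The source may hold more compounds than are shown below. What is called first, only, known or untested is meant among the compounds shown, and "the series" means these compounds.

In a functional assay on T-24 cells (Homo sapiens) for antiproliferative activity, read by MTT assay, with a stated time of 48 h (on this read-out lower numbers stand for stronger inhibition and higher numbers for weaker inhibition), compound 1 `O=C(Nc1cccc(CNc2nccnc2Cl)c1)Nc1ccc(F)c(Cl)c1` gives 4990 nM, compound 2 `Cc1ccc(NC(=O)Nc2cccc(CNc3nccnc3Cl)c2)c(C)c1` gives 9230 nM and compound 3 `O=C(Nc1cccc(CNc2nccnc2Cl)c1)Nc1ccccc1F` gives 7450 nM. Compound 3 has no separate place among these three values. Its measured steps are a 1.2-fold lower number from compound 2 to compound 3 (0.09 log units; within the scatter) and a 1.5-fold higher number from compound 1 to compound 3 (0.17 log units; within the scatter), and the remaining step is a 1.8-fold higher number from compound 1 to compound 2 (0.27 log units; within the scatter), so no order can be drawn within the set.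

The next step leads to compound 4 `Cc1ccc(NC(=O)Nc2cccc(CNc3nccnc3Cl)c2)cc1`. The change is 4-methylphenyl in place of 2-fluorophenyl on an amide-type nitrogen. The core of compound 1 is kept throughout.

All three measured steps bear on this change, since each is an exchange of groups at that same nitrogen. The closest partner of compound 4 is compound 2, which carries 2,4-dimethylphenyl there, and the relevant step is a 1.2-fold lower number from compound 2 to compound 3 (0.09 log units; within the scatter). None of the three exchanges left the scatter, so no step beyond the scatter is expected in this assay, and the data favour no direction.

The estimate amounts to a 1.1-fold lower number from compound 3 to compound 4 (0.03 log units; within the scatter), an expected step that is indistinguishable from no change. For compound 4 the estimated value is 7000 nM, with an expected range from 3800 nM to 13000 nM.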

Compound 4, half-maximal inhibitory concentration: 9820 nM
For compound 4 the middle estimate is 1.4-fold (0.15 log units) below the measured one; low and high end bracket the measured number.
By their numbers in this assay, from the lowest: compounds 1, 3, 2 and 4 (each within the scatter of the next).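

In this assay, 4-methylphenyl in place of 2-fluorophenyl on the amide-type nitrogen gives a 1.3-fold higher number from compound 3 to compound 4 (0.12 log units; within the scatter) and adds a group with no fluorine to the set, yet it does not separate from the others. The series now also holds a pair that differs by one small exchange, hydrogen in place of methyl on an aromatic carbon, which gives a 1.1-fold higher number from compound 2 to compound 4 (0.03 log units; within the scatter) and shows that this single methyl has no effect that can be read here; 4-methylphenyl in place of 3-chloro-4-fluorophenyl gives a 2.0-fold higher number from compound 1 to compound 4 (0.29 log units; within the scatter) and also stays within the scatter, so the four aryl groups at this nitrogen remain unresolved from one another. Nothing measured on these compounds offers an explanation for this flat response.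

All groups shown at this nitrogen are substituted phenyl rings, so the effect of a basic amine, a carboxylic acid or a longer alkyl chain there remains open. As far as these compounds go, it is also open whether changes elsewhere on the shared core would produce steps beyond the scatter in this assay and give this position a readable order.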